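The compounds below may be only part of what the source reports. "The series", "measured", "known", "first", "only" and "open" are said of these compounds alone.

Measured in a functional assay on HEK293 cells for agonist activity at D(4) dopamine receptor (Homo sapiens), read by FLIPR; a higher number here means that more compound is needed for the effect, a lower number that less compound is needed:

- compound 1, `Cc1cc(C(=O)NCN2CCC(c3cccc[n+]3[O-])CC2)ccc1F`: 50 nM
- compound 2, `O=C(CN1CCC(c2cccc[n+]2[O-])CC1)Nc1ccc(F)cc1F`: 103 nM
- compound 3, `CC(C)Oc1cccc(NC(=O)CN2CCC(c3cccc[n+]3[O-])CC2)c1`: 555 nM

Compound 1 gives the lowest number of the three in this assay. Compound 2 comes nearest to it, its value lying beyond the scatter above that of compound 1; compound 3 lies furthest away, well beyond the scatter. Going by the values given here, no single-point step between these measured compounds is available, so no comparison between them can be read as the effect of one change alone; only the two values of each pair stand as they are.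

The next compound in the series is compound 4, `O=C(NCN1CCC(c2cccc[n+]2[O-])CC1)c1cnccc1Cl`. It differs from compound 1 in one place:

4-chloropyridin-3-yl in place of 4-fluoro-3-methylphenyl on a carbonyl carbon

Among the compounds with values here, with no measured step of this type in the set, the size of the effect is open. The expectation is a moderate rise in the number for compound 4, somewhat beyond the scatter, rather than a drop. The step from compound 1 to compound 4 is estimated as a 3.0-fold higher number from compound 1 to compound 4 (0.48 log units; beyond the scatter). In this assay compound 4 is expected to give about 150 nM, with a range from 50 nM to 500 nM.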

Compound 4, half-maximal effective concentration: 1290 nM
Compound 4: the middle estimate sits 8.6-fold (0.93 log units) below what was measured, outside the stated range (above it).
By their numbers in this assay, from the lowest: compound 1; then compound 2; then compound 3; then compound 4.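

In this assay, placing 4-chloropyridin-3-yl instead of 4-fluoro-3-methylphenyl on the carbonyl carbon gives a 26-fold higher number from compound 1 to compound 4 (1.41 log units; beyond the scatter). Going by these compounds alone, this is the first single-place step, and it shows that the number is highly sensitive to the group at this position, which the earlier compounds, with no such step among them, could not show. The exchange alters several features at once: a ring of carbon only gives way to a ring with one hetero atom, a hydrogen-bond acceptor enters, chlorine replaces fluorine, and the methyl group leaves, and no measurement here bears on which of these accounts for the step.

The compounds shown do not separate these features; 4-chlorophenyl or unsubstituted pyridin-3-yl on the same carbonyl carbon would divide the contribution of the ring nitrogen from that of the chlorine. Also open, from the compounds shown here alone, is whether the same exchange would give a step of similar size on the differently arranged amide linker of compound 2 and compound 3.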